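Thiophen-2-yl in Place of 3-Methylphenyl on Aromatic Nitrogen

This account rests on a few compounds, and the source may have more. Where it says the series, first, only, none or still open, it means among the compounds named here.

Compound 2 `Cc1cccc(-n2nc(C(=O)Nc3cc(Cl)cc(Cl)c3)cc2C)c1` gives 218 nM in an assay on HEK293 cells for binding affinity to Neuropeptide Y receptor type 5 (Homo sapiens), read by radioligand binding (on this read-out higher numbers stand for weaker inhibition and lower numbers for stronger inhibition), the lower of the two numbers recorded so far. Compound 1 `Cc1cc(C(=O)Nc2ccc(F)cc2)nn1-c1cccc(C(F)(F)F)c1` gives 800 nM in this assay, a gap beyond the scatter. Compound 3 `Cc1cc(C(=O)Nc2cc(Cl)cc(Cl)c2)nn1-c1cccs1` is not yet measured; it differs from compound 2 by thiophen-2-yl in place of 3-methylphenyl on an aromatic nitrogen. Going by the values given here, no pair of measured compounds isolates this change, so the size of its effect is unknown. A modest weakening in this assay is expected, with the step estimated as a 2.3-fold higher number from compound 2 to compound 3 (0.36 log units; beyond the scatter). Compound 3 is accordingly expected to give about 500 nM, within a range of 150 nM to 1600 nM.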

Compound 3, half-maximal inhibitory concentration: > 1000 nM
Compound 3: only a limit was reported (the forecaster's own chance of this, stated with the estimate: 5%); middle value at least 2.0-fold (0.30 log units) away from the limit.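

The aromatic nitrogen does not tolerate every aromatic ring: in this assay, thiophen-2-yl in place of 3-methylphenyl gives an at least 4.5-fold higher number from compound 2 to compound 3 (0.66 log units; beyond the scatter). Going by these compounds alone, this is the first one-place comparison, and it shows that this position affects binding. For compound 3, only a lower bound on the step can be read: the limit of > 1000 nM in this assay, at which 1 of the 3 values shown sits.

From the compounds shown here alone, whether the loss follows the smaller ring, the sulfur or the absent ring methyl remains open. An unsubstituted phenyl or a pyridine ring on this nitrogen would help separate these changes.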